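A few compounds are considered here, and "the series" means these few. Any claim that something is new, unique, unknown or untested is made for them only; others in the source may bear on it.

Measured compounds:
- compound 1, `CCCCCCCCCO[C@@H]1[C@@H](N)[C@@H](OC[C@H](O)CN=[N+]=[N-])O[C@H](CN)[C@H]1OCCCCCCCCC`: 62.2%
- compound 2, `C=CCO[C@H]1O[C@H](CN)[C@@H](O)[C@H](O)[C@H]1N`: 82.2%

In a toxicity assay on the whole organism (J774 cells) for cytotoxicity, with Mus musculus as the target, read by MTT assay, with a stated time of 24 h, tested at 10 uM (a lower number here means a stronger effect, a higher number a weaker effect of the compound at the concentration tested), compound 1 gives 62.2% and stands lowest of the two numbers; compound 2, the nearest, gives 82.2%, a gap that lies beyond the scatter. Among the compounds with values here, no pair among the measured compounds differs in a single place, so no step size has been read from the measured set.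

The unmeasured compound 3, `CCCCCCCCCO[C@@H]1[C@@H](N)[C@@H](OC[C@H](O)CN)O[C@H](CN)[C@H]1OCCCCCCCCC`, differs from compound 1 by amino in place of azido on a saturated chain carbon, two bonds along the chain from an oxygen on a saturated carbon. Without a measured step of this kind in the series, the expectation rests on compound 1 alone. The step in this assay is expected to be small, with the number for compound 3 moving somewhat lower than that of compound 1, though a result within the scatter would not be surprising; the expected step is a number 8.2 percentage points lower from compound 1 to compound 3 (within the scatter). On that basis compound 3 is estimated at 54%, within a range from 36% to 72%.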

Compound 3, a percentage reported as activity, at one concentration (the size of the read-out at that concentration, not a potency): 88%
The estimate for compound 3 lay 34 percentage points below the measured number, outside the stated range (above it).
By their numbers in this assay, from the lowest: compound 1; then compounds 2 and 3 (each within the scatter of the next).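

In this assay, amino in place of azido on a saturated chain carbon, two bonds along the chain from an oxygen on a saturated carbon, gives a number 25.8 percentage points higher from compound 1 to compound 3 (beyond the scatter), so the far end of this chain is not a silent place: going from 3-azido-2-hydroxypropyl to 3-amino-2-hydroxypropyl weakens the effect at the concentration tested while the rest of the structure stays the same. Within the data shown here, this is the first single-place step, and it ties the stronger effect of compound 1 in this pair to the azido group, though it rests on one pair only. Nothing measured at hand accounts for the size or direction of this step.

Still open, on these data alone, is whether the step follows the presence of azido or the presence of amino, and a hydroxyl group or a guanidine on the same chain carbon would help separate the two. Also open, as far as these compounds go, is whether the step carries over to a shorter 2-azido-1-hydroxyethyl chain or to a longer chain bearing the same azido end.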